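The compounds below may be only part of what the source reports. "The series", "measured", "known", "first", "only" and "open" are said of these compounds alone.

Among the compounds with values here, in an in vitro ADME assay on microsomes from liver (Mus musculus) for metabolic stability, read by LC-MS, with a stated time of 15 min (on this read-out higher numbers stand for fast clearance and lower numbers for slow clearance), compound 2 `O=c1[nH]cc(-c2ccccc2)cc1-c1ccccc1` gives 1.23 mL.min-1.g-1, the only plain number among the two values shown. Compound 1 `O=c1ccc(-c2ccccc2)cn1-c1ccccc1` is recorded in this assay only as a limit, > 1.53 mL.min-1.g-1. Compound 3 `O=c1c(-c2ccccc2)cc(-c2ccccc2)cn1-c1ccccc1` differs from compound 2 by phenyl in place of hydrogen on an aromatic nitrogen. No step between two measured compounds is shown, so the size of this change cannot be read off directly. Compound 1 also carries a phenyl on its aromatic nitrogen, and it sits at the limit of > 1.53 mL.min-1.g-1 in this assay, at which 1 of the 2 values shown sits. On that basis compound 3 is expected to shift toward faster clearance, by an estimated 1.4-fold higher number from compound 2 to compound 3 (0.14 log units; within the scatter), a step likely near the edge of the usual scatter. For compound 3 in this assay the estimated value is 1.7 mL.min-1.g-1, within a range from 1 mL.min-1.g-1 to 2.8 mL.min-1.g-1, with a fair chance that only a limit is reported.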

Compound 3, intrinsic clearance in microsomes: 0.148 mL.min-1.g-1
Compound 3: the middle estimate sits 11-fold (1.06 log units) above what was measured; the whole stated range lies above it.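

In this assay, phenyl in place of hydrogen on the aromatic nitrogen brings an 8.3-fold lower number from compound 2 to compound 3 (0.92 log units; beyond the scatter), so a phenyl at this nitrogen goes with slower clearance here, not faster. The phenyl on the aromatic carbon matters as well, with an at least 10-fold lower number from compound 1 to compound 3 (1.01 log units; beyond the scatter), so the low number belongs to the pair of phenyl groups together and not to the nitrogen phenyl alone. Compound 1, which has the nitrogen phenyl without that carbon phenyl, is recorded only as a limit: the limit of > 1.53 mL.min-1.g-1 in this assay, at which 1 of the 3 values shown sits.

What lies behind the drop cannot be told from these three compounds. From the compounds shown here alone, it also stays open whether a methyl group or a longer alkyl chain on the aromatic nitrogen would go the same way as phenyl, or whether an amine or a carboxylic acid on the nitrogen phenyl would keep the number this low.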